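The source may hold more compounds than are shown below. What is called first, only, known or untested is meant among the compounds shown, and "the series" means these compounds.

Compound 1 `COc1ccc(CNc2nc3cc(N)cc(N)c3nc2-c2ccccc2)cc1OC` is measured in a functional assay on A549 cells (Homo sapiens) for inhibition, read by sulforhodamine B assay, with a stated time of 48 h (on this read-out lower numbers stand for stronger inhibition of growth and higher numbers for weaker inhibition of growth), and gives 50100 nM, which is the higher of the two numbers recorded; the other is compound 3 `COc1cc(CNc2nc3cc(N)cc(N)c3nc2-c2ccccc2)cc(OC)c1OC` at 33100 nM, and the methoxy added from compound 1 to compound 3 moves the number by a 1.5-fold lower number from compound 1 to compound 3 (0.18 log units; within the scatter). Compound 2 `CCOC(=O)[C@H](CCC(=O)O)NC(=O)c1ccc(Sc2nc3cc(N)cc(N)c3nc2-c2ccccc2)cc1` reports only a limit, < 100000 nM, as noted in the limit of < 100000 nM in this assay, at which 1 of the 3 values shown sits. Compound 4 `COc1ccc(CNc2nc3cc(N)cc(N)c3nc2-c2ccccc2)cc1` differs from compound 1 by hydrogen in place of methoxy on an aromatic carbon. For the measured compounds named here, the only comparable step, the methoxy addition in a 1.5-fold lower number from compound 1 to compound 3 (0.18 log units; within the scatter), stayed within the scatter, so no change beyond the scatter is expected in this assay from compound 1 to compound 4, an estimated step of a 1.1-fold higher number from compound 1 to compound 4 (0.04 log units; within the scatter). Compound 4 is therefore estimated at 55000 nM, with a likely range from 28000 nM to 110000 nM.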

Compound 4, concentration for total growth inhibition: 60300 nM
For compound 4 the middle estimate is 1.1-fold (0.04 log units) below the measured one; the range from low to high includes it.
By their numbers in this assay, from the lowest: compounds 3, 1 and 4 (each within the scatter of the next).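

In this assay, taking the methoxy off the aromatic carbon ortho to a methoxy group, so that 3,4-dimethoxyphenyl becomes 4-methoxyphenyl, gives a 1.2-fold higher number from compound 1 to compound 4 (0.08 log units; within the scatter) as the whole effect. This is the first change shown at this position, and like a 1.5-fold lower number from compound 1 to compound 3 (0.18 log units; within the scatter) at another place on the same ring, it stays within the scatter. Nothing shown gives a reason for the size of this step.

On these data alone, whether a hydroxyl, an amine or a carboxylic acid at this position would also stay within the scatter remains open. So does the effect of a longer alkoxy chain there.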